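Dropping a methoxy group from a metabolically stable core

A few compounds are considered here, and "the series" means these few. Any claim that something is new, unique, unknown or untested is made for them only; others in the source may bear on it.

Compound 1 `COc1nc(N)nc2c1c(-c1ccc3oc(N)nc3c1)nn2C(C)C` was examined in an ADME assay on microsomes from liver (Homo sapiens) for metabolic stability, read by LC-MS, with a stated time of 15 min, tested at 1 uM, in the presence of a further agent that is not named here; a higher number here means that more of the compound is left, a lower number that less of the compound is left. In this assay compound 1 gives > 95%, which is a limit of the assay rather than a number. Its companion compound 2 `CC(C)n1nc(-c2ccc3oc(N)nc3c2)c2c(N)nc(N)nc21` carries an amino in place of methoxy on an aromatic carbon; in this assay compound 2 gives > 95%, again a limit. The step that the two limits leave unreadable from compound 1 to compound 2 therefore cannot be read in size, since (the limit of > 95% in this assay, at which 2 of the 2 values shown sit). Compound 3 `CC(C)n1nc(-c2ccc3oc(N)nc3c2)c2cnc(N)nc21` differs from compound 1 by hydrogen in place of methoxy on an aromatic carbon. Within the data shown here, the only measured step, from compound 1 to compound 2, is of unreadable size, so no direction beyond the scatter can be inferred for compound 3 in this assay. Compound 3 is therefore expected to sit near the limit, with an estimated step of a number at least 5 percentage points lower from compound 1 to compound 3 (that floor lies within the scatter). Compound 3 is estimated at 90%, ranging from 70% to 99%.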

Compound 3, percent of the compound remaining: 94%
Compound 3: middle estimate off by 4 percentage points, on the low side; the range from low to high includes it.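

In this assay, among these compounds, compound 3 gives 94%, the first value at this position that is a number and not a limit. With hydrogen in place of methoxy the result is a number at least 1 percentage points lower from compound 1 to compound 3 (that floor lies within the scatter), and with hydrogen in place of amino it is a number at least 1 percentage points lower from compound 2 to compound 3 (that floor lies within the scatter). The position on the aromatic carbon next to the ring nitrogen can therefore carry a bare hydrogen with no step beyond the scatter, so neither the methoxy nor the amino group is required for a high percentage of compound remaining here.

As far as these compounds go, how an ethoxy group, a chlorine atom or a carboxylic acid at this position would read remains open. The true size of these steps also remains open because the values of the two comparison compounds are limits: the limit of > 95% in this assay, at which 2 of the 3 values shown sit.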